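Fluoro for Hydrogen on the Methylsulfonylphenyl Ring

A few compounds are considered here, and "the series" means these few. Any claim that something is new, unique, unknown or untested is made for them only; others in the source may bear on it.

Two measured compounds, compound 1 `COc1cc2nc(OC3CCN(C(=O)OC(C)(C)C)CC3)nc(Nc3ccc(S(C)(=O)=O)cc3)c2cc1OC` and compound 2 `COc1cc2nc(Nc3ccc(S(C)(=O)=O)cc3)nc(OC3CCN(C(=O)OC(C)(C)C)CC3)c2cc1OC`, share a common core and were tested in a functional assay on HEK293 cells for agonist activity at Glucose-dependent insulinotropic receptor (Homo sapiens), read by cAMP accumulation, with a stated time of 60 min; on this read-out higher numbers stand for larger maximal responses and lower numbers for smaller maximal responses. In this assay compound 1 gives 17.9%, and in this assay compound 2 gives 20.6%. Compound 2 holds the higher of the two numbers, but its gap to compound 1 lies within the usual scatter, so the two values are best read as alike. Compound 3 `COc1cc2nc(Nc3ccc(S(C)(=O)=O)cc3F)nc(OC3CCN(C(=O)OC(C)(C)C)CC3)c2cc1OC` has not yet been measured. It differs from compound 2 in one place: fluoro in place of hydrogen on an aromatic carbon. Within the data shown here, no step between measured compounds is available, so nothing measured shows how such an exchange plays out here. Among the measured compounds shown here, with no measured step to lean on, the step of a number 1.4 percentage points higher from compound 2 to compound 3 (within the scatter) is expected to be small, in either direction, and within the scatter. Compound 3 is therefore estimated to give about 22% in this assay, with a likely range from 10% to 38%.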

Compound 3, largest response reached (Emax), in percent of the reference or control that the assay uses: 19.7%
Estimate against measurement, compound 3: 2.3 percentage points above, and the stated range covers the measured number.
By their numbers in this assay, from the lowest: compounds 1, 3 and 2 (each within the scatter of the next).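

In this assay, among these compounds, the exchange of hydrogen for fluoro, on the aromatic carbon ortho to a large group and meta to the methylsulfonyl group, gives a number 0.9 percentage points lower from compound 2 to compound 3 (within the scatter) and is the first measured step at this position. Turning 4-(methylsulfonyl)phenyl into 2-fluoro-4-(methylsulfonyl)phenyl therefore leaves the largest response unchanged within the scatter, so this position accepts a fluoro without a readable effect on this read-out. Nothing measured here offers an explanation for this outcome.

The compounds shown leave open whether a chloro, methoxy or nitrile on the same aromatic carbon would behave as fluoro does. Also open, as far as these compounds go, is whether a carboxylic acid or an amide in place of the methylsulfonyl group would move the response beyond the scatter.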